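The source may report more compounds than this note shows. Statements on the series, on what has been measured and on what is new or still open speak of the compounds shown alone.

Measured compounds:
compound 1 `CC1=C(C(=O)OCc2ccccc2)C(c2ccsc2)NC(=O)N1` gives 25%
compound 2 `CC1=C(C(=O)C2CC2)C(c2ccsc2)NC(=O)N1` gives 1%
compound 3 `CCN(CC)C(=O)C1=C(C)NC(=O)NC1c1ccsc1` gives 35%

All three were tested in an assay on membranes from HeLa cells for displacement of a labelled ligand from adenosine receptor A3 (Homo sapiens), read by scintillation counting, with a stated time of 180 min, tested at 1 uM; a lower number here means less inhibition, a higher number more inhibition at the concentration tested (going by the name of the read-out). Among them compound 3 stands highest; compound 1 lies within the usual scatter of it, while compound 2 lies well below, with the step of a number 34 percentage points higher from compound 2 to compound 3 (beyond the scatter) marking the only single-site change measured so far. Among the measured compounds shown here, compound 1 and compound 2 differ in one place too, and their two values show the ester well above the ketone, though no step is computed for that pair.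

Compound 4 `CC1=C(C(=O)OC2CCC2)C(c2ccsc2)NC(=O)N1` differs from compound 3 as follows: cyclobutyloxy in place of diethylamino on a carbonyl carbon. The step from compound 2 to compound 3 shows that the group on this carbonyl carbon matters greatly in this assay. The only measured ester, compound 1, stands within the scatter of compound 3, so the amide-to-ester change is expected to cost little or nothing beyond the scatter. Compound 4 is therefore estimated at 22%, in a range from 5% to 40%, meaning an expected step of a number 13 percentage points lower from compound 3 to compound 4 (beyond the scatter).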

Compound 4, a percentage reported as inhibition, at one concentration (the size of the read-out at that concentration, not a potency): 3%
Beside the measured number, compound 4's estimate is 19 percentage points above it, and the stated range ends above it.
By their numbers in this assay, from the lowest: compounds 2 and 4 (each within the scatter of the next); then compounds 1 and 3 (each within the scatter of the next).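

In this assay the step of a number 32 percentage points lower from compound 3 to compound 4 (beyond the scatter) shows that an ester on this carbonyl carbon does not by itself stay level with the diethylamino amide, as compound 1 alone had seemed to suggest. Among the compounds shown here, the step of a number 22 percentage points lower from compound 1 to compound 4 (beyond the scatter) shows that the group on the ester oxygen matters, with cyclobutyl in place of benzyl as the only change. With a step of a number 2 percentage points higher from compound 2 to compound 4 (within the scatter) the cyclobutyloxy ester cannot be told apart from the cyclopropyl ketone, and these two stand together at the low end of this set.

It remains open where a methoxy group, a phenoxy group or a piperidine amide on this carbonyl carbon would fall among these numbers. Nothing given here explains why the numbers differ.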